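Swapping one small heteroaryl ring on a shared benzoxazole-type core

The source may hold more compounds than are shown below. What is called first, only, known or untested is meant among the compounds shown, and "the series" means these compounds.

Measured compounds:
compound 1 `Cc1ccc(-c2nc(=O)o[nH]2)c(-c2ccc([C@@H](C)N(CC3CC3)c3nc4c(C(=O)O)cccc4o3)cc2)c1` 3.2 nM
compound 2 `CCCCN(c1nc2c(C(=O)O)cccc2o1)[C@H](C)c1ccc(-c2cc(Cl)ccc2-c2nc(=O)o[nH]2)cc1` 1.2 nM
compound 3 `CCCCN(c1nc2c(-c3nccn3C)cccc2o1)[C@H](C)c1ccc(-c2ccccc2-c2nnn[nH]2)cc1` 10 nM

Of the compounds shown here, three have been tested in a functional assay on CAL1 cells for inhibition of chemerin-like receptor 1 (Homo sapiens), with a stated time of 45 min; on this read-out lower numbers stand for stronger inhibition and higher numbers for weaker inhibition. Compound 1 gives 3.2 nM and compound 2 gives 1.2 nM. Compound 3 gives 10 nM, the highest of the three numbers, and its gaps to compound 1 and to compound 2 both lie beyond the usual scatter of this assay, so compound 3 is the weakest inhibitor among the measured set.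

Compound 4 `CCCCN(c1nc2c(-c3ccccn3)cccc2o1)[C@H](C)c1ccc(-c2ccccc2-c2nnn[nH]2)cc1` has not yet been measured. It differs from compound 3 in one place: pyridin-2-yl in place of 1-methyl-1H-imidazol-2-yl on an aromatic carbon. Among the measured compounds shown here, no other pair in this set shows what such a swap does, so the expectation for compound 4 rests only on its closeness to compound 3. Because compound 3 gives 10 nM, compound 4 is expected to land near that figure, with a step of about a 1.5-fold higher number from compound 3 to compound 4 (0.18 log units; within the scatter) in this assay, which is within the scatter and so no clear direction is claimed. The estimate for compound 4 is 15 nM, with a range from 4 nM to 60 nM.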

Compound 4, half-maximal inhibitory concentration: 110 nM
Beside the measured number, compound 4's estimate is 7.3-fold (0.87 log units) below it; the whole stated range lies below it.
By their numbers in this assay, from the lowest: compound 2; then compound 1; then compound 3; then compound 4.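

In this assay the ring on this aromatic carbon of the shared core proves not to be freely exchangeable: pyridin-2-yl in place of 1-methyl-1H-imidazol-2-yl gives an 11-fold higher number from compound 3 to compound 4 (1.04 log units; beyond the scatter) even though both groups have the same number of heavy atoms and neither carries a net charge. The earlier compounds shown here could not show this, as no two of them differ in only one place. The swap changes ring size and the count of hetero atoms and hydrogen-bond acceptors together, and nothing available explains the step.

The compounds shown leave open whether the five-membered ring itself or its methyl group matters more, which a 1H-imidazol-2-yl group without the methyl could test. They also leave open how other small rings, such as thiazol-2-yl or pyrimidin-2-yl, would behave at this position.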